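Methyl to ethyl in a cytotoxicity series

This account rests on a few compounds, and the source may have more. Where it says the series, first, only, none or still open, it means among the compounds named here.

Compound 1 `Cc1ccc(C(=O)/C=C/c2ccc3c(c2)B(O)OC3)cc1` heads a set of three compounds measured in an ADME assay on L929 cells (Mus musculus) for cytotoxicity, read by resazurin assay, with a stated time of 72 h; on this read-out lower numbers stand for stronger inhibition and higher numbers for weaker inhibition. In this assay compound 1 gives > 10 ug/mL, a limit of the assay and not a number. Compound 2 `Nc1cccc(C(=O)/C=C/c2ccc3c(c2)B(O)OC3)c1` gives 10 ug/mL in this assay. Compound 3 `O=C(/C=C/c1ccc2c(c1)B(O)OC2)c1ccccc1O` gives > 10 ug/mL in this assay, again a limit rather than a number. The steps of a number no higher from compound 1 to compound 2 (the limit leaves the size open), a step that the two limits leave unreadable from compound 1 to compound 3 and a number no lower from compound 2 to compound 3 (the limit leaves the size open) remain unreadable in size because of the limit of > 10 ug/mL in this assay, at which 2 of the 3 values shown sit. Compound 4 `CCc1ccc(C(=O)/C=C/c2ccc3c(c2)B(O)OC3)cc1` differs from compound 1 by methyl in place of hydrogen on a saturated chain carbon bound to an aromatic carbon. Within the data shown here, none of the measured steps touches this part of the structure; all concern the group on the carbonyl carbon. The chemist therefore expects a step that the limit leaves unreadable from compound 1 to compound 4, nothing beyond the scatter, and most likely once more a limit. The estimate for compound 4 is 15 ug/mL, between 5 ug/mL and 40 ug/mL.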

Compound 4, half-maximal inhibitory concentration: > 10 ug/mL
Compound 4 was reported as a limit; the forecaster's own chance of this, stated with the estimate: 70%; the middle value lies beyond the limit too.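

No size can be read for the step between compound 1 and compound 4, because both values are limits: the limit of > 10 ug/mL in this assay, at which 3 of the 4 values shown sit. Going by these compounds, how far either compound lies past that limit in this assay stays open, and so does whether the methyl changes the read-out at all.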